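A few compounds are considered here, and "the series" means these few. Any claim that something is new, unique, unknown or untested is made for them only; others in the source may bear on it.

Measured so far in a functional assay on MCF7 cells (Homo sapiens) for inhibition, read by MTT assay, with a stated time of 72 h; on this read-out higher numbers stand for weaker inhibition of growth and lower numbers for stronger inhibition of growth:
compound 1 `COc1ccc(CNC(=O)/C(C#N)=C/c2ccc[nH]2)cc1`, 34000 nM
compound 2 `COc1ccc(CNC(=O)/C(C#N)=C/c2ccc(Cl)o2)cc1`, 9000 nM
compound 3 `COc1ccc(CNC(=O)/C(C#N)=C/c2ccc(-c3ccccc3)o2)cc1`, 3000 nM

Compound 2 holds the second highest of the three numbers in this assay. Its nearest neighbour is compound 3, reached by a 3.0-fold lower number from compound 2 to compound 3 (0.48 log units; beyond the scatter), and its furthest is compound 1, separated by a 3.8-fold lower number from compound 1 to compound 2 (0.58 log units; beyond the scatter). Both steps lie beyond the scatter, and both change the group carried on the double-bonded chain carbon bound to a double-bonded chain carbon, so that position is where this small series has so far moved.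

Compound 4 `COc1ccc(CNC(=O)/C(C#N)=C/c2ccc(Cl)cc2)cc1` is not yet measured. Relative to compound 2 the change is 4-chlorophenyl in place of 5-chlorofuran-2-yl on a double-bonded chain carbon bound to a double-bonded chain carbon. For the measured compounds named here, no measured pair exchanges one aromatic ring for another at this place; the two measured steps only show that alterations here shift this assay by modest amounts. Going by the values given here, with no direct precedent, the number for compound 4 is expected to stay close to that of compound 2, and the expected step of a 1.1-fold higher number from compound 2 to compound 4 (0.05 log units; within the scatter) may well fall within the scatter. In this assay compound 4 is estimated at 10000 nM, with an expected range from 3000 nM to 30000 nM.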

Compound 4, concentration for 50% growth inhibition: 11000 nM
Compound 4: middle estimate off by 1.1-fold (0.04 log units), on the low side; measured number inside the range.
By their numbers in this assay, from the lowest: compound 3; then compounds 2 and 4 (each within the scatter of the next); then compound 1.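

In this assay, for the compounds shown here, the step of a 1.2-fold higher number from compound 2 to compound 4 (0.09 log units; within the scatter) is the first direct exchange of one chlorine-bearing aromatic ring for another on a double-bonded chain carbon bound to a double-bonded chain carbon, and it leaves the two compounds unresolved from each other. The one-ring-for-another change from 1H-pyrrol-2-yl to 4-chlorophenyl gives a 3.1-fold lower number from compound 1 to compound 4 (0.49 log units; beyond the scatter) and so shows that the six-membered ring of carbon only reads as the 5-chlorofuran-2-yl group does against compound 1, with no hetero atom in the ring needed to hold that level in this small set. No supporting data bear on the cause of either step.

Still open, going by these compounds, is whether phenyl in place of chloro on the 4-chlorophenyl ring of compound 4 would repeat the gain seen on the furan ring in the step of a 3.0-fold lower number from compound 2 to compound 3 (0.48 log units; beyond the scatter) in this assay. Also open, on these data alone, is how the number would respond to an amine or a carboxylic acid in place of chloro on either ring.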